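This account rests on a few compounds, and the source may have more. Where it says the series, first, only, none or still open, it means among the compounds named here.

In an ADME assay on HepG2 2.2.15 cells (Homo sapiens) for cytotoxicity (on this read-out higher numbers stand for lower toxicity in this test and lower numbers for higher toxicity in this test), compound 3 (`O=CCc1c(-c2ccccc2Cl)c2cc(Cl)ccc2[nH]c1=O`) gives 120000 nM as the higher of the two true numbers in hand. In this assay compound 1 (`O=c1c(CCO)c(-c2ccccc2Cl)c2cc(Cl)ccc2n1-c1ccccc1`) gives the lower number at 26000 nM on the same read-out. Compound 2 (`O=c1c(CCO)c(-c2ccccc2Cl)c2cc(Cl)ccc2n1-c1c(F)cccc1F`) gives > 2300000 nM and this is a limit of the assay, not a number.

The step to compound 4 (`CC(C)C(=O)OCCc1c(-c2ccccc2Cl)c2cc(Cl)ccc2[nH]c1=O`) is ((isopropylcarbonyl)oxy)methyl in place of formyl on a saturated chain carbon bound to an aromatic carbon and reads as ((isopropylcarbonyl)oxy)methyl in place of formyl on a saturated chain carbon bound to an aromatic carbon. Among the compounds with values here, the only measured step is an at least 88-fold higher number from compound 1 to compound 2 (1.94 log units; beyond the scatter) and although large, it is a change of 2,6-difluorophenyl in place of phenyl on an aromatic nitrogen. That is a different place, so it sets no size for this change. Within the data shown here, no measured step covers this chain, so the expectation stays anchored on compound 3 at 120000 nM with no shift beyond the scatter in this assay anticipated. The expected change is a 1.5-fold lower number from compound 3 to compound 4 (0.18 log units; within the scatter) with no firm direction. In this assay the estimated value for compound 4 is 80000 nM with an expected range from 25000 nM to 250000 nM as working figures.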

Compound 4, half-maximal cytotoxic concentration: 62000 nM
For compound 4 the middle estimate is 1.3-fold (0.11 log units) above the measured one; the range from low to high includes it.
By their numbers in this assay, from the lowest: compound 1; then compounds 4 and 3 (each within the scatter of the next). At a limit, above all of these: compound 2.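

In this assay, a 1.9-fold lower number from compound 3 to compound 4 (0.29 log units; within the scatter) is the only step shown at this place, on a saturated chain carbon bound to an aromatic carbon. It shows that, for this pair, the exchange of formyl with 2 heavy atoms for ((isopropylcarbonyl)oxy)methyl with 7 heavy atoms leaves the read-out within the scatter, so the larger ester-bearing chain brings no measurable change in this test. The limit held by compound 2 concerns a different place, and nothing in hand gives a cause for this step.

Open, as far as these compounds go, is how an amine, a carboxylic acid or a longer chain at this place would read in this assay. Also open, from the compounds shown here alone, is whether 2,6-difluorophenyl on the aromatic nitrogen would give a comparable shift on the core of compound 4.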